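Phenyl for oxolan-2-yl on the amide carbonyl: expected lipophilicity

The source may report more compounds than this note shows. Statements on the series, on what has been measured and on what is new or still open speak of the compounds shown alone.

Compound 3, `Cc1cc(NC(=O)C2CCCO2)nn1Cc1cc(Cl)ccc1OCc1ccccc1`, gives in a physicochemical assay for lipophilicity, at pH 7.4 (on this read-out higher numbers stand for higher lipophilicity and lower numbers for lower lipophilicity), only a limit of the assay, > 3.7, and no number. Compound 1, `CC(=O)Nc1cc(C)n(Cc2cc(Cl)ccc2OCc2ccccc2)n1`, likewise sits at a limit of this assay, > 3.7. Compound 2, `Cc1cc(NC(=O)CC2CCCCC2)nn1Cc1cc(Cl)ccc1OCc1ccccc1`, gives a number in this assay, 3.2. Among the steps between these three, cyclohexyl in place of hydrogen on the saturated chain carbon bound to the carbonyl gave a number at least 0.50 log units lower from compound 1 to compound 2 (beyond the scatter), oxolan-2-yl in place of cyclohexylmethyl on the carbonyl carbon gave a number at least 0.50 log units higher from compound 2 to compound 3 (beyond the scatter), and oxolan-2-yl in place of methyl on the carbonyl carbon gave a step that the two limits leave unreadable from compound 1 to compound 3 because of the limit of > 3.7 in this assay, at which 2 of the 3 values shown sit.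

Compound 4, `Cc1cc(NC(=O)c2ccccc2)nn1Cc1cc(Cl)ccc1OCc1ccccc1`, differs from compound 3 by phenyl in place of oxolan-2-yl on a carbonyl carbon. For the measured compounds named here, the steps that bear on this change are the two that alter the group on the carbonyl carbon, and each of them was at least modest; yet compound 3 stands at a limit, so the direction from it cannot be read off the numbers. Compound 4 is expected to remain at or past that limit, with an estimated step that the limit leaves unreadable from compound 3 to compound 4. Compound 4 is therefore estimated at 4.1, between 3.6 and 4.6.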

Compound 4, distribution coefficient: > 3.7
Compound 4: no number, only a limit; the forecaster's own chance of this, stated with the estimate: 75%; the middle value does not contradict the limit.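

Phenyl now joins methyl and oxolan-2-yl as a third group on this carbonyl carbon that gives only a limit of this assay: compound 4 gives > 3.7, which is a limit and not a number. Against cyclohexylmethyl, phenyl in place of that group gave a number at least 0.50 log units higher from compound 2 to compound 4 (beyond the scatter), so an aromatic ring of carbon only on the carbonyl carbon ends up on the same side of compound 2 as the two groups seen earlier, and among the four compounds compound 2 alone goes against this pattern by giving a number. The steps from compound 3 to compound 4 and from compound 1 to compound 4 cannot be read, and the order of phenyl, oxolan-2-yl and methyl at this position stays unresolved: the limit of > 3.7 in this assay, at which 3 of the 4 values shown sit.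

The compounds shown leave open how far past the limit compound 1, compound 3 and compound 4 lie. They also leave open whether another group on this carbonyl carbon, such as an amine, a carboxylic acid or a longer chain, would bring the read-out back to a number, as cyclohexylmethyl does in compound 2.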